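Removing a Piperazine Methyl: Expected Gain in Solubility

This account rests on a few compounds, and the source may have more. Where it says the series, first, only, none or still open, it means among the compounds named here.

Measured compounds:
compound 1, `CN1CCN(c2ccc(/C=C3/SC(Nc4ccccc4)=NC3=O)cc2)CC1`, 0.35 ug/mL
compound 2, `O=C1N=C(Nc2ccccc2)S/C1=C/c1ccc(N2CCNCC2)cc1`, 1.68 ug/mL
compound 3, `CN1CCN(c2ccc(/C=C3/SC(N(C)c4ccccc4)=NC3=O)cc2)CC1`, 18.9 ug/mL

All three were tested in a physicochemical assay (Homo sapiens) for solubility, with a stated time of 18 h, at pH 7.4; a higher number here means a more soluble compound, a lower number a less soluble compound. Compound 1 gives the lowest number of the three. Two single changes lead away from it. The first, (hydrogen in place of methyl on an amine nitrogen in a ring), takes compound 1 to compound 2 and brings a 4.8-fold higher number from compound 1 to compound 2 (0.68 log units; beyond the scatter). The second, (methyl in place of hydrogen on a nitrogen on an aromatic ring), takes compound 1 to compound 3 and brings a 54-fold higher number from compound 1 to compound 3 (1.73 log units; beyond the scatter). Compound 3 therefore stands highest of the three, with compound 2 a good deal lower and compound 1 lower still.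

Compound 4, `CN(C1=NC(=O)/C(=C\c2ccc(N3CCNCC3)cc2)S1)c1ccccc1`, has not yet been measured. It differs from compound 3 by hydrogen in place of methyl on an amine nitrogen in a ring. This is the same change that separates compound 1 from compound 2: in both pairs the place is described in identical words, so it is the same change, seen in two pairs. The two cores, those of compound 1 and compound 3, differ by methyl in place of hydrogen on a nitrogen on an aromatic ring.

Within the data shown here, only one measured example of this change exists, so the expectation rests on it alone. For compound 4 an upward step of about a 3.7-fold higher number from compound 3 to compound 4 (0.57 log units; beyond the scatter) is expected, mirroring the step seen from compound 1 to compound 2. Compound 4 is thus estimated at 70 ug/mL, with a plausible range from 20 ug/mL to 250 ug/mL.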

Compound 4, solubility: 3.89 ug/mL
Compound 4: middle estimate off by 18-fold (1.26 log units), on the high side; the whole stated range lies above it.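

In this assay, the change from 4-methylpiperazin-1-yl to piperazin-1-yl gave a rise on the core of compound 1 (a 4.8-fold higher number from compound 1 to compound 2 (0.68 log units; beyond the scatter)), whereas the same change on the core of compound 3 gave a fall (a 4.9-fold lower number from compound 3 to compound 4 (0.69 log units; beyond the scatter)), so the direction of the step did not carry from one core to the other. The methyl on a nitrogen on an aromatic ring also behaves differently across the two pairs: it gives a smaller rise among the piperazin-1-yl compounds (a 2.3-fold higher number from compound 2 to compound 4 (0.36 log units; beyond the scatter)) than among the 4-methylpiperazin-1-yl compounds (a 54-fold higher number from compound 1 to compound 3 (1.73 log units; beyond the scatter)), which shows that the two changes do not simply add up in these four compounds. These four compounds do not show whether such a reversal would appear on any other core, and nothing available here explains it.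

The compounds shown leave open what an ethyl or an acetyl group on the same ring nitrogen would do on each of the two cores. They also leave open whether an ethyl group, in place of the methyl on the nitrogen on an aromatic ring, would give the same reversal.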